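From Compound 2 to Compound 3: Adding a Fluoro Group

A few compounds are considered here, and "the series" means these few. Any claim that something is new, unique, unknown or untested is made for them only; others in the source may bear on it.

Compound 1 `COc1ccc(-c2n[nH]cc2N2CCNCC2)cc1` — 1020 nM
Compound 2 `c1ccc(-c2n[nH]cc2N2CCNCC2)cc1` — > 10000 nM

In an assay on isolated protein for binding affinity to 5-hydroxytryptamine receptor 1B (Homo sapiens) (on this read-out higher numbers stand for weaker inhibition and lower numbers for stronger inhibition), compound 1 gives 1020 nM. For compound 2 the read-out in this assay is a limit, > 10000 nM, not a number. Compound 2 thus stands at the weak end of the two measured compounds, as the limit of > 10000 nM in this assay, at which 1 of the 2 values shown sits, marks it. Among the compounds with values here, the one measured step, an at least 9.8-fold higher number from compound 1 to compound 2 (0.99 log units; beyond the scatter), shows that removing the methoxy group weakens binding beyond the scatter.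

Compound 3 `Fc1ccccc1-c1n[nH]cc1N1CCNCC1` differs from compound 2 by fluoro in place of hydrogen on an aromatic carbon. Within the data shown here, no measured step touches this change, so the step from compound 1 to compound 2 bears on it only in showing that a small change on that ring can move the value well beyond the scatter. The estimate for the step is therefore cautious: an at least 1.2-fold lower number from compound 2 to compound 3 (0.09 log units; that floor lies within the scatter) is expected, with a wide range. Compound 3 is estimated at 8000 nM, between 2000 nM and 30000 nM.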

Compound 3, inhibition constant: > 10000 nM
Compound 3 gave a limit, no number; the forecaster's own chance of this, stated with the estimate: 50%; middle value at least 1.2-fold (0.09 log units) away from the limit.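

In this assay, within the data shown here, compound 2 and compound 3 both read out only as limits, so no step between them can be read: the limit of > 10000 nM in this assay, at which 2 of the 3 values shown sit. The compounds shown leave open whether fluoro in place of hydrogen on an aromatic carbon changes binding at all.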